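Chloro on compound 2: a step out from a limit

The source may report more compounds than this note shows. Statements on the series, on what has been measured and on what is new or still open speak of the compounds shown alone.

In an ADME assay on HCT-116 cells (Homo sapiens) for cytotoxicity, read by CellTiter-Glo, with a stated time of 72 h (on this read-out lower numbers stand for stronger inhibition and higher numbers for weaker inhibition), compound 1 `CC1CCN(C2CCN(S(=O)(=O)c3ccc(C#N)cc3)CC2)CC1` gives > 5000 nM as a limit. Compound 2 `CC1CCN(C2CCN(S(=O)(=O)c3ccc(-c4ccccc4)cc3)CC2)CC1` gives > 5000 nM as a limit too, so it stands only at that limit and not on a number. The evidence so far is the limit of > 5000 nM in this assay, at which 2 of the 2 values shown sit, and nothing more. Among the compounds with values here, the one measured step is a step that the two limits leave unreadable from compound 1 to compound 2 and offers no size to carry forward. Compound 3 `CC1CCN(C2CCN(S(=O)(=O)c3ccc(-c4ccc(Cl)cc4)cc3)CC2)CC1` differs from compound 2 by chloro in place of hydrogen on an aromatic carbon in the form of chloro in place of hydrogen on an aromatic carbon, para to a large group, which also reads as phenyl to 4-chlorophenyl. With no readable step bearing on this change, no shift beyond the scatter is expected in this assay and no direction is favoured. The expected size is a step that the limit leaves unreadable from compound 2 to compound 3 on this estimate. Compound 3 is expected at 6000 nM with an estimated range of 2500 nM to 15000 nM and a good chance of ending up only as a limit.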

Compound 3, half-maximal inhibitory concentration: > 5000 nM
Compound 3: a limit, no number; the forecaster's own chance of this, stated with the estimate: 80%; the middle value lies beyond the limit too.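

In this assay compound 3 gives > 5000 nM, which is a limit. No new step can be read among compound 1, compound 2 and compound 3. What remains open is whether cyano, phenyl and 4-chlorophenyl differ at all on this read-out, as all three compounds share one limit: the limit of > 5000 nM in this assay, at which 3 of the 3 values shown sit.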